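The compounds below may be only part of what the source reports. "The series", "measured", "known", "first", "only" and "open" are said of these compounds alone.

Compound 1 `COc1cc(CNc2nc3cc(N)cc(N)c3nc2-c2ccccc2)cc(OC)c1OC` gives in a functional assay on HOP-62 cells (Homo sapiens) for inhibition, read by sulforhodamine B assay, with a stated time of 48 h (on this read-out higher numbers stand for weaker inhibition of growth and lower numbers for stronger inhibition of growth), a value that is a limit of the assay, < 50200 nM.
Compound 2 `COc1ccc(CNc2nc3cc(N)cc(N)c3nc2-c2ccccc2)cc1` gives in this assay 34700 nM.
Compound 3 `COc1ccc(Sc2nc3cc(N)cc(N)c3nc2-c2ccccc2)cc1` gives in this assay a value that is a limit of the assay, < 100000 nM.

Compound 3 therefore stands not at a number but at a limit, (the limit of < 100000 nM in this assay, at which 1 of the 3 values shown sits); of the three values shown, a second one is also a limit, (the limit of < 50200 nM in this assay, at which 1 of the 3 values shown sits), so only compound 2 carries a plain number. Going by the values given here, compound 3 shares its core with compounds 1 and 2, but no step between two measured compounds is recorded, and the difference between compound 3 and compound 4 `Nc1cc(N)c2nc(-c3ccccc3)c(Sc3ccc(F)cc3)nc2c1` is fluoro in place of methoxy on an aromatic carbon. Among the compounds with values here, with no measured step of this kind to lean on, the step from compound 3 to compound 4 in this assay is expected to be small, no larger than the scatter, and in no fixed direction. Compound 4 is accordingly estimated at 45000 nM, within a range from 12000 nM to 100000 nM, with a fair chance that the assay again reports only a limit; the expected step is a step that the limit leaves unreadable from compound 3 to compound 4.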

Compound 4, concentration for total growth inhibition: 34700 nM
Compound 4: the middle estimate sits 1.3-fold (0.11 log units) above what was measured, within the range that was stated.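

In this assay no step can be read from compound 3 to compound 4, because the value of compound 3 is a limit of the assay and not a number: the limit of < 100000 nM in this assay, at which 1 of the 4 values shown sits. The compounds shown leave open how large the change from methoxy to fluoro is, and in which direction it runs.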